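The compounds below may be only part of what the source reports. "The series", "measured", "known", "first", "only" and "open" are said of these compounds alone.

Three compounds built on a shared core were tested in a functional assay on HepG2 cells (Homo sapiens) for cytotoxicity, read by MTT assay, with a stated time of 48 h (on this read-out higher numbers stand for weaker inhibition and lower numbers for stronger inhibition), and a fourth awaits its number. Compound 1 `COc1cc(-c2nnc3n2NC(c2cccs2)C(C(=O)c2ccc(C)cc2)S3)cc(OC)c1OC` gives 3700 nM in this assay. Compound 2 `COc1cc(-c2nnc3n2NC(c2cccs2)C(C(=O)c2ccccc2)S3)cc(OC)c1OC` reaches only a limit of the assay, > 100000 nM, in this assay. Compound 3 `COc1cc(-c2nnc3n2NC(c2ccco2)C(C(=O)c2ccccc2)S3)cc(OC)c1OC` gives 90900 nM in this assay. Compound 4 `COc1cc(-c2nnc3n2NC(c2ccco2)C(C(=O)c2ccc(C)cc2)S3)cc(OC)c1OC` has not yet been measured in this assay.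

Compound 1 differs from compound 2 by methyl in place of hydrogen on an aromatic carbon. That change produced an at least 27-fold lower number from compound 2 to compound 1 (1.43 log units; beyond the scatter). Since compound 2 sits at the limit of > 100000 nM in this assay, at which 1 of the 3 values shown sits, the true size of that step is known only as a floor and may well be larger.

Compound 3 differs from compound 2 in its core by furan-2-yl in place of thiophen-2-yl on a saturated ring carbon. That change produced an at least 1.1-fold lower number from compound 2 to compound 3 (0.04 log units; that floor lies within the scatter), so the two values show no separation that can be read as a difference.

Compound 4 differs from compound 3 by methyl in place of hydrogen on an aromatic carbon, the same change that separates compound 2 from compound 1, made on the core that compound 3 carries. The study therefore expects a step of a 26-fold lower number from compound 3 to compound 4 (1.41 log units; beyond the scatter), resting on an at least 27-fold lower number from compound 2 to compound 1 (1.43 log units; beyond the scatter) and on compound 3 with its starting value of 90900 nM. Because the earlier step is bounded only by the limit of > 100000 nM in this assay, at which 1 of the 3 values shown sits, its floor is taken as the central guess while room is left for a larger drop. Compound 4 is expected to give about 3500 nM in this assay, most likely between 900 nM and 15000 nM.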

Compound 4, half-maximal inhibitory concentration: 17400 nM
Compound 4: the middle estimate sits 5.0-fold (0.70 log units) below what was measured, and the stated range ends below it.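

In this assay the methyl in place of hydrogen on an aromatic carbon again gives a drop, a 5.2-fold lower number from compound 3 to compound 4 (0.72 log units; beyond the scatter), so the direction of the change carries from one core to the other while its size does not: the same change on two cores in this assay, an at least 27-fold lower number (1.43 log units; beyond the scatter) from compound 2 to compound 1 and a 5.2-fold lower number (0.72 log units; beyond the scatter) from compound 3 to compound 4, at least 5.1-fold (0.71 log units) apart, beyond the scatter of two such steps.
The core change itself behaves differently once the methyl is present, for furan-2-yl in place of thiophen-2-yl gives a 4.7-fold higher number from compound 1 to compound 4 (0.67 log units; beyond the scatter), whereas the same swap without the methyl shows no separation that can be read: the same change on two cores in this assay, an at least 1.1-fold lower number (0.04 log units; that floor lies within the scatter) from compound 2 to compound 3 and a 4.7-fold higher number (0.67 log units; beyond the scatter) from compound 1 to compound 4, at least 5.1-fold (0.71 log units) apart, beyond the scatter of two such steps.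
Compound 2 stands at a limit of the assay, > 100000 nM, so the gap between the two methyl steps is known only as a floor, and the pairs show that the two changes do not add up independently in these four compounds without showing why: the limit of > 100000 nM in this assay, at which 1 of the 4 values shown sits.

The compounds shown leave open whether a chloro or methoxy group at the same place on the six-membered aromatic ring would follow the methyl, and whether an ethyl group would extend its effect. They also leave open how the methyl step would run on a core carrying phenyl in place of thiophen-2-yl or furan-2-yl on the saturated ring carbon.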